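A few compounds are considered here, and "the series" means these few. Any claim that something is new, unique, unknown or untested is made for them only; others in the source may bear on it.

Measured compounds:
Compound 1, `Cc1nc2c(OCc3ccccc3)cccn2c1N`: in a functional assay on the whole organism with Canis familiaris (Canis lupus familiaris) as the target, at a dose of 8 mg/kg by the oral route (a higher number here means a stronger effect of the compound at the dose given, a lower number a weaker effect), compound 1 gives 96%.
Compound 2, `CCCCc1nc2c(OCc3ccccc3)cccn2c1N`: compound 2 gives 0%.
Compound 3, `Cc1nc2c(OCc3ccc(F)cc3)cccn2c1N`: compound 3 gives 93%.

Compound 3 stands second highest of the three numbers. Its nearest neighbour is compound 1, with a number 3 percentage points lower from compound 1 to compound 3 (within the scatter), so the two cannot be told apart. Furthest away is compound 2, which gives 0%, far from the value of compound 3.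

The next compound is compound 4, `Cc1nc2c(OCc3ccc(C(F)(F)F)cc3)cccn2c1N`. It differs from compound 3 in one place: trifluoromethyl in place of fluoro on an aromatic carbon.

Two measured steps exist. The step of a number 96 percentage points lower from compound 1 to compound 2 (beyond the scatter) is large, but it alters the saturated chain carbon, not the benzene ring that is changed here. The step of a number 3 percentage points lower from compound 1 to compound 3 (within the scatter) is the closer precedent: a substituent entering the same aromatic carbon left the read-out within the scatter. On that basis a further change at the same aromatic carbon is expected to move this assay little, with no direction beyond the scatter, though a single precedent leaves room for a larger shift.

Compound 4 is expected to give about 85%, within a range of 45% to 98%. The step this estimate implies, a number 8 percentage points lower from compound 3 to compound 4 (within the scatter), is expected to be small.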

Compound 4, a percentage reported as inhibition, in the whole organism at one dose (the size of the read-out at that dose, not a potency): 8%
Compound 4: middle estimate off by 77 percentage points, on the high side; measured number below the stated range.
By their numbers in this assay, from the lowest: compounds 2 and 4 (each within the scatter of the next); then compounds 3 and 1 (each within the scatter of the next).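

Working note: at the aromatic carbon para to a large group, the outcome in this assay depends strongly on which group is present, and the earlier fluoro result does not extend to trifluoromethyl. Fluoro in place of hydrogen gives a number 3 percentage points lower from compound 1 to compound 3 (within the scatter), whereas trifluoromethyl in place of fluoro gives a number 85 percentage points lower from compound 3 to compound 4 (beyond the scatter), and trifluoromethyl in place of hydrogen gives a number 88 percentage points lower from compound 1 to compound 4 (beyond the scatter), so this carbon cannot be treated as freely open to substitution. No available data bear on the cause of this loss.

The compounds shown leave open whether the read-out falls gradually or abruptly between fluoro, with 1 heavy atom, and trifluoromethyl, with 4 heavy atoms, and a chloro, methyl or methoxy group on the same carbon would help to separate those cases. Because each read-out comes from a single oral dose and is not a potency, they also leave open how compound 4 would behave at other doses.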